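Nitro in place of chloro: notes on the series

The source may report more compounds than this note shows. Statements on the series, on what has been measured and on what is new or still open speak of the compounds shown alone.

compound 1 `COc1ccc2c(c1)nc(/C=C/C(=O)/C=C/c1ccc(OC)c(O)c1)n2C` gives 4200 nM
compound 2 `COc1ccc(/C=C/C(=O)/C=C/c2nc3cc(Cl)ccc3n2C)cc1O` gives 4100 nM

In a functional assay on HepG2 cells (Homo sapiens) for cytotoxicity, read by MTT assay, with a stated time of 48 h (a higher number here means a weaker inhibitor, a lower number a stronger inhibitor), compound 2 gives 4100 nM and sits within the scatter of compound 1, so neither stands apart on the two numbers available. Compound 3 `COc1ccc(/C=C/C(=O)/C=C/c2nc3cc([N+](=O)[O-])ccc3n2C)cc1O` differs from compound 2 by one change nitro in place of chloro on an aromatic carbon with the nitro on an aromatic carbon of a six-membered aromatic ring of carbon only. Within the data shown here, one measured step bears on this: a 1.0-fold lower number from compound 1 to compound 2 (0.01 log units; within the scatter) for chloro in place of methoxy on an aromatic carbon, and it lies within the scatter. Among the measured compounds shown here, no nitro compound has been measured yet, so this single step is thin evidence. On that basis no shift beyond the scatter is expected in this assay and the range stays wide. The expected step is a 1.2-fold lower number from compound 2 to compound 3 (0.07 log units; within the scatter) as estimated here. For compound 3 the expected value is 3500 nM within a range of 1500 nM to 8000 nM as estimated.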

Compound 3, half-maximal inhibitory concentration: 4600 nM
For compound 3 the middle estimate is 1.3-fold (0.12 log units) below the measured one; the range from low to high includes it.
By their numbers in this assay, from the lowest: compounds 2, 1 and 3 (each within the scatter of the next).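

In this assay, the aromatic carbon that carries chloro in compound 2 also takes nitro (a 1.1-fold higher number from compound 2 to compound 3 (0.05 log units; within the scatter)), so replacing 1 chlorine with 3 heavy atoms and 2 hydrogen-bond acceptors leaves the number within the scatter. Nitro against methoxy reads the same way (a 1.1-fold higher number from compound 1 to compound 3 (0.04 log units; within the scatter)), and chloro, methoxy and nitro at this position now all lie within the scatter of one another. No measurement on these compounds offers an explanation for this flat reading.

The compounds shown leave open whether an amine, a carboxylic acid or a longer chain on this carbon would move the number beyond the scatter. They also leave open whether changes elsewhere on the shared core would do so in this assay.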